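Series notes: methoxy in place of dimethylamino

This account rests on a few compounds, and the source may have more. Where it says the series, first, only, none or still open, it means among the compounds named here.

Measured so far:
compound 1 `Cc1nc2ccccc2c(=O)n1NCc1nnc(/N=C/c2ccc(N(C)C)cc2)s1` 50%
compound 2 `Cc1nc2ccc(Br)cc2c(=O)n1NCc1nnc(/N=C/c2ccc(N(C)C)cc2)s1` 50%
compound 3 `COc1cccc(C2SCC(=O)N2c2nnc(CNn3c(C)nc4ccc(Br)cc4c3=O)s2)c1` 60%

In a functional assay on the whole organism (strain albino) with Rattus norvegicus as the target, in the maximal electroshock model, with a stated time of 1 h, at a dose of 30 mg/kg by the intraperitoneal route (on this read-out higher numbers stand for more inhibition at the one dose given (going by the name of the read-out) and lower numbers for less inhibition), compound 2 gives 50%, level with compound 1 at the digits printed, and compound 3 gives 60%, a number within the scatter of compound 2. Among the measured compounds shown here, the one step measured in this assay, no change at the digits printed from compound 1 to compound 2 (within the scatter), is a bromo in place of hydrogen on an aromatic carbon and leaves the read-out unchanged within the scatter.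

Compound 4 `COc1ccc(/C=N/c2nnc(CNn3c(C)nc4ccc(Br)cc4c3=O)s2)cc1` differs from compound 2 by methoxy in place of dimethylamino on an aromatic carbon. For the measured compounds named here, no measured step touches this part of the structure, so there is no direct guide. With all three numbers lying within the scatter of one another, the step from compound 2 to compound 4 is expected to be no change at the digits printed from compound 2 to compound 4 (within the scatter), none beyond the scatter. Compound 4 is therefore estimated at 50%, with a range from 30% to 70%.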

Compound 4, a percentage reported as inhibition, in the whole organism at one dose (the size of the read-out at that dose, not a potency): 50%
Estimate against measurement, compound 4: no gap at the digits printed, and the stated range covers the measured number.
By their numbers in this assay, from the lowest: compounds 1, 2, 4 and 3 (each within the scatter of the next).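

In this assay, among the compounds shown here, methoxy in place of dimethylamino on the aromatic carbon para to a large group gives no change at the digits printed from compound 2 to compound 4 (within the scatter), the first reading at this position. At this one dose, the read-out of the bromo compounds therefore does not depend on keeping dimethylamino here. Nothing measured bears on why the read-out holds. From the compounds shown here alone, it remains open whether a carboxylic acid or a primary amine at this position would also leave the read-out within the scatter. Going by these compounds, the same change on the core of compound 1, without bromo, also remains open.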